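The compounds below may be only part of what the source reports. "The series", "measured", "known", "first", "only" and "open" are said of these compounds alone.

Measured so far in a functional assay on the whole organism (blood, strain Wistar-Okamoto) with Rattus norvegicus as the target, with a stated time of 5 days; on this read-out higher numbers stand for an effect only at larger amounts of compound and lower numbers for an effect already at smaller amounts:
compound 1 `CCCCC/N=C(\NC#N)Nc1cccnc1` gives 20 mg/kg
compound 2 `N#CN/C(=N\C1CCCCC1)Nc1cccnc1` gives 20 mg/kg
compound 3 `CCOCC/N=C(\NC#N)Nc1cccnc1` gives > 20 mg/kg, which is a limit of the assay and not a number

Compound 1 stands level with compound 2 at the digits shown; the step of no change at the digits printed from compound 1 to compound 2 (within the scatter) lies within the scatter, cyclohexyl in place of pentyl on a double-bonded nitrogen. The step of a number no lower from compound 1 to compound 3 (the limit leaves the size open) leaves its size open, resting on (the limit of > 20 mg/kg in this assay, at which 1 of the 3 values shown sits). The step of a number no lower from compound 2 to compound 3 (the limit leaves the size open) reads the same way.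

Compound 4 `N#CN/C(=N\CC1CCCO1)Nc1cccnc1` differs from compound 1 by oxolan-2-yl in place of butyl on a saturated chain carbon bound to a double-bonded nitrogen. Among the compounds with values here, the steps that bear on this change are the two into compound 3, each bringing an oxygen into the chain on the double-bonded nitrogen and each ending at the limit, whereas the ring alone in compound 2 gave no change. Compound 4 carries both a ring and an oxygen. Because a number no lower from compound 1 to compound 3 (the limit leaves the size open) points towards an effect only at larger amounts, the expected step for compound 4 is a 1.5-fold higher number from compound 1 to compound 4 (0.18 log units; within the scatter), with a fair chance that only a limit is again reported. The estimate for compound 4 is 30 mg/kg, ranging from 15 mg/kg to 60 mg/kg.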

Compound 4, minimum effective dose: 50 mg/kg
Estimate against measurement, compound 4: 1.7-fold (0.22 log units) below; the range from low to high includes it.
By their numbers in this assay, from the lowest: compounds 1 and 2 (each within the scatter of the next); then compound 4.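

Within the data shown here, with oxolan-2-yl on a saturated chain carbon bound to a double-bonded nitrogen, this assay gives the first readable steps at this position that lie beyond the scatter (a 2.5-fold higher number from compound 1 to compound 4 (0.40 log units; beyond the scatter); a 2.5-fold higher number from compound 2 to compound 4 (0.40 log units; beyond the scatter)). The cyclohexyl ring showed no such step (no change at the digits printed from compound 1 to compound 2 (within the scatter)), so among these compounds a ring on this nitrogen does not by itself go with a higher number, while compound 4, whose ring carries an oxygen, does. Among these compounds, compound 3 gives > 20 mg/kg, which is a limit and not a number, and the steps to and from it, including the one to compound 4, cannot be read.

As far as these compounds go, whether the oxygen or the ring size and its spacing from the nitrogen sets the step stays open. A cyclopentylmethyl or a pyrrolidin-2-ylmethyl group in place of (oxolan-2-yl)methyl would separate these.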